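Methyl to Trifluoromethyl on the Shared Core

The source may report more compounds than this note shows. Statements on the series, on what has been measured and on what is new or still open speak of the compounds shown alone.

Measured compounds in an assay on mitochondria from L6 cells (Rattus norvegicus) for activation, with a stated time of 90 min; on this read-out higher numbers stand for an effect only at larger amounts of compound and lower numbers for an effect already at smaller amounts:
compound 1, `Fc1cccc(Nc2nc3nonc3nc2Nc2ccccc2F)c1`: 190 nM
compound 2, `Oc1nc2nonc2nc1Nc1ccccc1F`: 12500 nM
compound 3, `Cc1cc(Nc2nc3nonc3nc2O)ccc1OCC(F)(F)F`: 7000 nM

Compound 3 sits close to compound 2, the two numbers lying within the scatter of each other, while compound 1 gives a far lower number than either. Within the data shown here, the single step known, a 66-fold higher number from compound 1 to compound 2 (1.82 log units; beyond the scatter), concerns a different position and does not bear on the change under study. Compound 4, `Oc1nc2nonc2nc1Nc1ccc(OCC(F)(F)F)c(C(F)(F)F)c1`, differs from compound 3 by trifluoromethyl in place of methyl on an aromatic carbon. Among the measured compounds shown here, with no measured step of this kind, the account expects for compound 4 a change of a 1.2-fold lower number from compound 3 to compound 4 (0.07 log units; within the scatter) in this assay, that is, none beyond the scatter. Compound 4 is therefore estimated at 6000 nM, within the range 2000 nM to 20000 nM.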

Compound 4, half-maximal effective concentration: 4000 nM
Compound 4: the middle estimate sits 1.5-fold (0.18 log units) above what was measured, within the range that was stated.
By their numbers in this assay, from the lowest: compound 1; then compounds 4, 3 and 2 (each within the scatter of the next, the first and the last beyond it).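

In this assay, among these compounds, trifluoromethyl in place of methyl on the aromatic carbon ortho to the 2,2,2-trifluoroethoxy group gives a 1.8-fold lower number from compound 3 to compound 4 (0.24 log units; within the scatter), the first reading of any change at this position. This position therefore accepts the larger trifluoromethyl group with no shift beyond the scatter. No evidence on the reason is at hand.

Going by these compounds, it remains open whether an amine, a carboxylic acid or a chlorine atom at this place would move the number beyond the scatter. On these data alone, it is also open whether the same exchange would behave alike with the (3-fluorophenyl)amino group of compound 1 in place of the hydroxy group.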